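This account rests on a few compounds, and the source may have more. Where it says the series, first, only, none or still open, it means among the compounds named here.

Measured so far in an in vitro functional assay on 1321-N1 cells for agonist activity at Free fatty acid receptor 1 (Homo sapiens), read by fluorescence, spectrophotometry and calcium flux; a lower number here means that less compound is needed, a higher number that more compound is needed for the effect:

compound 1, `Cc1ccccc1-c1cc(C#Cc2ccc(CCC(=O)O)cc2)ccn1`, 1070 nM
compound 2, `O=C(O)CCc1ccc(C#Cc2ccnc(Cl)c2)cc1`, 295 nM
compound 3, `Cc1cc(C#Cc2ccc(CCC(=O)O)cc2)ccn1`, 1120 nM

Compound 3 gives the highest of the three numbers in this assay. Against compound 1 the difference is a 1.0-fold higher number from compound 1 to compound 3 (0.02 log units; within the scatter), within the scatter; against compound 2 it is a 3.8-fold higher number from compound 2 to compound 3 (0.58 log units; beyond the scatter), beyond it.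

Compound 4, `O=C(O)CCc1ccc(C#Cc2ccnc(Oc3ccccc3)c2)cc1`, differs from compound 3 as follows: phenoxy in place of methyl on an aromatic carbon. The step that bears most on it is the one from a larger aryl group to methyl at the same carbon, a 1.0-fold higher number from compound 1 to compound 3 (0.02 log units; within the scatter), which stayed within the scatter. The chloro step, a 3.8-fold higher number from compound 2 to compound 3 (0.58 log units; beyond the scatter), was modest but points the other way. Compound 4 is therefore expected to land close to compound 3, with a step of about a 1.2-fold lower number from compound 3 to compound 4 (0.09 log units; within the scatter), a change not beyond the scatter. The estimate for compound 4 is 900 nM, with a range from 300 nM to 3000 nM.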

Compound 4, half-maximal effective concentration: 479 nM
The estimate for compound 4 lay 1.9-fold (0.27 log units) above the measured number, within the range that was stated.
By their numbers in this assay, from the lowest: compounds 2 and 4 (each within the scatter of the next); then compounds 1 and 3 (each within the scatter of the next).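

In this assay phenoxy in place of methyl gives a 2.3-fold lower number from compound 3 to compound 4 (0.37 log units; beyond the scatter) and phenoxy in place of 2-methylphenyl gives a 2.2-fold lower number from compound 1 to compound 4 (0.35 log units; beyond the scatter) so at this carbon next to the ring nitrogen, a large aromatic group does not by itself set the number. Phenoxy in place of chloro gives a 1.6-fold higher number from compound 2 to compound 4 (0.21 log units; within the scatter) so these two groups are not told apart here.

As far as these compounds go, whether the difference from 2-methylphenyl follows the oxygen link or the missing methyl stays open, as does the outcome with a methoxy group or an amine at this carbon. No measurement shown accounts for these steps.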